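Para substituent series: halogen to tert-butyl on the aryl ring

This account rests on a few compounds, and the source may have more. Where it says the series, first, only, none or still open, it means among the compounds named here.

Two compounds of the shared core have been run so far. In a functional assay on HeLa cells (Homo sapiens) for cytotoxicity, read by MTT assay (on this read-out lower numbers stand for stronger inhibition and higher numbers for weaker inhibition), compound 1 `CCOC(=O)C12C(=O)OCC=C1COC2c1ccc(Cl)cc1` gives 118000 nM, and compound 2 `CCOC(=O)C12C(=O)OCC=C1COC2c1ccc(Br)cc1` gives 48700 nM. Within the data shown here, the only step measured, a 2.4-fold lower number from compound 1 to compound 2 (0.38 log units; beyond the scatter), sets compound 2 at the lowest of the two numbers, with compound 1 the nearest neighbour at a higher number beyond the scatter.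

Compound 3 `CCOC(=O)C12C(=O)OCC=C1COC2c1ccc(C(C)(C)C)cc1` differs from compound 2 by tert-butyl in place of bromo on an aromatic carbon. Among the measured compounds shown here, no measured step exchanges a halogen for an alkyl group, so the one step on record bears on this change only loosely: it shows that the group para to the large group moves the number beyond the scatter in this assay when enlarged from chloro to bromo. On that basis compound 3 is expected to give about 35000 nM in this assay, between 10000 nM and 120000 nM, which means an estimated step of a 1.4-fold lower number from compound 2 to compound 3 (0.14 log units; within the scatter).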

Compound 3, half-maximal inhibitory concentration: 25400 nM
Compound 3: the middle estimate sits 1.4-fold (0.14 log units) above what was measured, within the range that was stated.
By their numbers in this assay, from the lowest: compounds 3 and 2 (each within the scatter of the next); then compound 1.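

Working notes: the place on an aromatic carbon para to a large group takes a group with no halogen at all, since in this assay tert-butyl, with 4 heavy atoms, sits within the scatter of bromo, with 1 heavy atom (a 1.9-fold lower number from compound 2 to compound 3 (0.28 log units; within the scatter)). Against chloro the same group gives a step beyond the scatter (a 4.6-fold lower number from compound 1 to compound 3 (0.67 log units; beyond the scatter)), so compound 2 and compound 3 both stand apart from compound 1. No supporting data are available to explain these differences.

Still open, from the compounds shown here alone, is whether an amine, a carboxylic acid or a longer chain at this place would stay level with bromo and tert-butyl or move away from them. The shift from compound 1 also rests on chloro alone, so fluoro or an unsubstituted hydrogen could place it in context.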